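This account rests on a few compounds, and the source may have more. Where it says the series, first, only, none or still open, it means among the compounds named here.

Measured so far in a functional assay on MCF7 cells (Homo sapiens) for cytotoxicity, read by MTT assay, with a stated time of 72 h; a higher number here means a weaker inhibitor, a lower number a stronger inhibitor:
compound 1, `CCCCCCCCNc1nc(SCc2ccc(C(F)(F)F)cc2)nc2ccccc12`: 26100 nM
compound 2, `FC(F)(F)c1ccc(CSc2nc(Nc3ccccc3C(F)(F)F)c3ccccc3n2)cc1`: > 50000 nM
compound 3, `O=[N+]([O-])c1ccc(Nc2nc(SCc3ccc(C(F)(F)F)cc3)nc3ccccc23)cc1`: 17900 nM

Compound 2 stands at the limit of > 50000 nM in this assay, at which 1 of the 3 values shown sits, a limit of the assay and not a number, so its true place is open-ended. The unmeasured compound 4, `FC(F)(F)c1ccc(CSc2nc(Nc3ccc(C(F)(F)F)cc3)c3ccccc3n2)cc1`, differs from compound 2 by 4-(trifluoromethyl)phenyl in place of 2-(trifluoromethyl)phenyl on a nitrogen on an aromatic ring. The step that bears on this is an at least 2.7-fold lower number from compound 2 to compound 3 (0.44 log units; beyond the scatter), where 4-nitrophenyl replaced the same 2-(trifluoromethyl)phenyl; the steps of an at least 1.9-fold higher number from compound 1 to compound 2 (0.28 log units; that floor lies within the scatter) and a 1.5-fold lower number from compound 1 to compound 3 (0.16 log units; within the scatter) point the same way, though only the first goes beyond the scatter. Compound 4 is therefore expected to give a lower number than compound 2, estimated as an at least 2.0-fold lower number from compound 2 to compound 4 (0.30 log units; that floor lies within the scatter). The estimated value of compound 4 is 25000 nM, with a likely range from 8000 nM to 80000 nM.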

Compound 4, half-maximal inhibitory concentration: 5100 nM
The estimate for compound 4 lay 4.9-fold (0.69 log units) above the measured number; measured number below the stated range.
By their numbers in this assay, from the lowest: compound 4; then compounds 3 and 1 (each within the scatter of the next). At a limit, above all of these: compound 2.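

Placing 4-(trifluoromethyl)phenyl in place of 2-(trifluoromethyl)phenyl on the nitrogen, with the same atoms joined differently, gives an at least 9.8-fold lower number from compound 2 to compound 4 (0.99 log units; beyond the scatter) in this assay and shows that where the trifluoromethyl sits on this ring matters. Compound 2 stands at a limit and not a number: the limit of > 50000 nM in this assay, at which 1 of the 4 values shown sits. The new group also gives a 3.5-fold lower number from compound 3 to compound 4 (0.55 log units; beyond the scatter) when it carries trifluoromethyl in place of nitro, and a 5.1-fold lower number from compound 1 to compound 4 (0.71 log units; beyond the scatter) when it replaces octyl. On these data alone, whether an amine or a carboxylic acid in place of that trifluoromethyl would lower the number further remains open.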